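A few compounds are considered here, and "the series" means these few. Any claim that something is new, unique, unknown or untested is made for them only; others in the source may bear on it.

Measured in a functional assay on HL-60 cells (Homo sapiens) for cytotoxicity, read by luminescence and CellTiter-Glo, with a stated time of 3 days; a higher number here means a weaker inhibitor, a lower number a stronger inhibitor:
Compound 1 `N#Cc1ccc(NC(=O)c2cc(-c3ccncc3)ccc2O)cc1`: 5410 nM
Compound 2 `O=C(Nc1ccc(OC(F)(F)F)c(Cl)c1)c1ccc(C(F)(F)F)cc1O`: 380 nM
Compound 3 `Cc1cc(C#N)ccc1NC(=O)c1ccc2cccnc2c1O`: 710 nM

Compound 1 has the highest number of the three, and both compound 2 and compound 3 lie below it beyond the scatter. Compound 4 `N#Cc1ccc(NC(=O)c2cc(C(F)(F)F)ccc2O)cc1` keeps the core of compound 1 but has trifluoromethyl in place of pyridin-4-yl on an aromatic carbon, para to a hydroxy group (trifluoromethyl in place of pyridin-4-yl on an aromatic carbon). Going by the values given here, no measured pair isolates this change, so the expectation is loose. Compound 2 also carries trifluoromethyl and gives 380 nM, though it differs from compound 1 elsewhere too. A moderate move towards a lower number in this assay, beyond the scatter, is therefore expected. The estimated step is a 3.6-fold lower number from compound 1 to compound 4 (0.56 log units; beyond the scatter). For compound 4 the expected value is 1500 nM, within a range of 500 nM to 4000 nM.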

Compound 4, half-maximal inhibitory concentration: 3120 nM
The estimate for compound 4 lay 2.1-fold (0.32 log units) below the measured number; low and high end bracket the measured number.
By their numbers in this assay, from the lowest: compounds 2 and 3 (each within the scatter of the next); then compounds 4 and 1 (each within the scatter of the next).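

In this assay, the only single-place comparison shown puts trifluoromethyl in place of pyridin-4-yl on an aromatic carbon, para to a hydroxy group, and the step is a 1.7-fold lower number from compound 1 to compound 4 (0.24 log units; within the scatter). At this position, then, the assay does not separate the six-membered aromatic ring from trifluoromethyl, a group with no ring. Nothing available explains this result. Going by these compounds, whether an amine, a carboxylic acid or a longer alkyl chain on this carbon would shift the number beyond the scatter remains open.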